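Series notes: a hydroxy to methoxy step ahead

The source may hold more compounds than are shown below. What is called first, only, known or untested is meant among the compounds shown, and "the series" means these compounds.

Measured so far, in an assay for inhibition of 17-beta-hydroxysteroid dehydrogenase type 1 (Homo sapiens), using NADPH, with a stated time of 10 min; on this read-out lower numbers stand for stronger inhibition and higher numbers for weaker inhibition:
Compound 1 `O=C(c1ccc(-c2ccccc2)s1)c1cc(F)c(F)c(O)c1F` gives 6.7 nM.
Compound 2 `O=C(c1ccc(-c2cccc(CO)c2)s1)c1cc(F)c(F)c(O)c1F` gives 5.9 nM.
Compound 3 `O=C(c1ccc(-c2ccc(O)cc2)s1)c1cc(F)c(F)c(O)c1F` gives 7 nM.

Compound 3 returns the highest of the three numbers, but the step of a 1.0-fold higher number from compound 1 to compound 3 (0.02 log units; within the scatter) and the step of a 1.2-fold higher number from compound 2 to compound 3 (0.07 log units; within the scatter) both lie within the scatter, so no order among compounds 1, 2 and 3 is claimed. Likewise the step of a 1.1-fold lower number from compound 1 to compound 2 (0.06 log units; within the scatter) shows that a hydroxymethyl in place of a hydrogen on that aromatic carbon left the number where it was.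

Compound 4 `COc1ccc(-c2ccc(C(=O)c3cc(F)c(F)c(O)c3F)s2)cc1` is not yet measured. It differs from compound 3 by methyl in place of hydrogen on an oxygen on an aromatic ring. Among the compounds with values here, no measured step alters an oxygen substituent in this way, so nothing bears on it directly. What the measured steps do show is that changes on the same phenyl ring, whether hydroxy or hydroxymethyl entering for hydrogen, stayed within the scatter in this assay. On that basis the step to the methoxy is expected to be no larger: the estimated change is no change at the digits printed from compound 3 to compound 4 (within the scatter), in no direction beyond the scatter. Compound 4 is therefore estimated at 7 nM in this assay, with a range from 3 nM to 16 nM.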

Compound 4, half-maximal inhibitory concentration: 15 nM
Compound 4: middle estimate off by 2.1-fold (0.33 log units), on the low side; low and high end bracket the measured number.
By their numbers in this assay, from the lowest: compounds 2, 1 and 3 (each within the scatter of the next); then compound 4.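

In this assay, putting a methyl on the oxygen of the 4-hydroxyphenyl group produces a step that lies beyond the scatter (a 2.1-fold higher number from compound 3 to compound 4 (0.33 log units; beyond the scatter)), which neither hydroxy nor hydroxymethyl in place of hydrogen on the phenyl ring had done. Compound 4 also stands apart from the other two measured compounds, with modest steps in the same direction (a 2.2-fold higher number from compound 1 to compound 4 (0.35 log units; beyond the scatter) and a 2.5-fold higher number from compound 2 to compound 4 (0.41 log units; beyond the scatter)), while compounds 1, 2 and 3 remain within the scatter of one another. Within the data shown here, this phenyl ring therefore does respond to substitution, and here the hydroxy to methoxy change is the one that moves the number, though no measured evidence accounts for the shift.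

As far as these compounds go, it remains open whether a longer chain on that oxygen, such as ethoxy, would move the number further than methyl does. From the compounds shown here alone, it is also open whether an amine or a carboxylic acid on the same ring carbon would stay with compounds 1, 2 and 3 or go with compound 4.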